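The compounds below may be only part of what the source reports. "The series", "measured", "known", "first", "only" and "open" are said of these compounds alone.

Measured so far in an assay on isolated protein for agonist activity at Bile acid receptor (Homo sapiens), read by TR-FRET, with a stated time of 3 h, in the absence of a further agent; a lower number here means that less compound is needed, a higher number that more compound is needed for the effect:

- compound 1 `CC(Oc1cccc(NC(=O)c2ccc(Oc3ccccc3)cc2)c1)C(=O)O`: compound 1 gives > 10000 nM, which is a limit of the assay.
- compound 2 `COc1ccccc1C(=O)Nc1cccc(C(=O)O)c1`: compound 2 gives > 10000 nM, which is a limit of the assay.
- compound 3 `COc1cccc(C(=O)Nc2cccc(C(=O)O)c2)c1`: compound 3 gives 1040 nM.

Among the measured compounds shown here, compound 3 therefore stands as the only compound with an actual number in this assay; the remaining entries are the limit of > 10000 nM in this assay, at which 2 of the 3 values shown sit. For the measured compounds named here, no pair of measured compounds differs in a single place, so no measured step can be sized from these data, and nothing in the set yet tells how a change at the alkoxy chain plays out.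

Compound 4 `CCCCOc1cccc(C(=O)Nc2cccc(C(=O)O)c2)c1` has not been measured. It differs from compound 3 by propyl in place of hydrogen on a saturated chain carbon bound to an oxygen on an aromatic ring. Going by the values given here, with no measured step of this kind available, the expectation rests on the number for compound 3 alone: a modest gain, roughly at the edge of the scatter, is expected, a 2.3-fold lower number from compound 3 to compound 4 (0.36 log units; beyond the scatter), though an outcome flat with compound 3 would not be surprising. In this assay compound 4 is expected at 450 nM, with a range from 120 nM to 2500 nM.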

Compound 4, half-maximal effective concentration: 3150 nM
Compound 4: the middle estimate sits 7.0-fold (0.85 log units) below what was measured; measured number outside the range, above it.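

Among the compounds shown here, the first readable step at this position goes against a gain: in this assay, methoxy to butoxy gives a 3.0-fold higher number from compound 3 to compound 4 (0.48 log units; beyond the scatter). The number at this saturated chain carbon bound to an oxygen on an aromatic ring therefore responds to the propyl extension, though the step is modest and compound 4 still gives a number rather than a limit. For the compounds shown here, compound 1 and compound 2 each sit at a limit and not at a number, so no step to either can be read: the limit of > 10000 nM in this assay, at which 2 of the 4 values shown sit.

From the compounds shown here alone, with a single step, it remains open whether the number rises steadily with chain length, and an ethoxy or a propoxy group would be needed to show this. Also open, going by these compounds, is how a chain ending in a hydroxyl group or an amine would read at this place.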